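This account rests on a few compounds, and the source may have more. Where it says the series, first, only, none or still open, it means among the compounds named here.

So far, in a functional assay on MCF7 cells (Homo sapiens) for inhibition, read by MTT assay, with a stated time of 3 days (on this read-out lower numbers stand for stronger inhibition and higher numbers for weaker inhibition), the values are:
compound 1 `C=CCOc1cc(/C=C\c2cc(OC)c(OC)c(OC)c2)ccc1OC` gives 12000 nM
compound 2 `COc1ccc(/C=C\c2cc(OC)c(OC)c(OC)c2)cc1OCc1ccccc1` gives 59000 nM
compound 3 `COc1cccc(/C=C/CCCOc2cc(/C=C\c3cc(OC)c(OC)c(OC)c3)ccc2OC)c1` gives 41000 nM

Compound 3 stands second highest of the three numbers, within the scatter of compound 2 and beyond it from compound 1. Compound 4 `COCOc1cccc(/C=C/CCCOc2cc(/C=C\c3cc(OC)c(OC)c(OC)c3)ccc2OC)c1` carries 3-(methoxymethoxy)phenyl in place of 3-methoxyphenyl (methoxy in place of hydrogen on a saturated chain carbon bound to an oxygen on an aromatic ring). Going by the values given here, no measured step makes this exact change. The nearest steps swap the whole group: a 4.9-fold higher number from compound 1 to compound 2 (0.69 log units; beyond the scatter) and a 3.4-fold higher number from compound 1 to compound 3 (0.53 log units; beyond the scatter) are modest, while a 1.4-fold lower number from compound 2 to compound 3 (0.16 log units; within the scatter) stays within the scatter. On that last step from compound 2, no shift beyond the scatter is expected in this assay here, the expected step being a 1.0-fold lower number from compound 3 to compound 4 (0.01 log units; within the scatter) in size. Compound 4 is estimated at 40000 nM with an expected range from 17000 nM to 90000 nM on this read-out.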

Compound 4, half-maximal inhibitory concentration: 8000 nM
Beside the measured number, compound 4's estimate is 5.0-fold (0.70 log units) above it; measured number outside the range, below it.
By their numbers in this assay, from the lowest: compounds 4 and 1 (each within the scatter of the next); then compounds 3 and 2 (each within the scatter of the next).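

In this assay, going by these compounds alone, a 5.1-fold lower number from compound 3 to compound 4 (0.71 log units; beyond the scatter) is the first step to a lower number beyond the scatter, and it comes from methoxymethoxy in place of methoxy. The earlier steps shown here either gave higher numbers or stayed within the scatter, whereas compound 4 keeps the long chain and still stands within the scatter of compound 1, so the long chain alone does not set the number. No evidence on the cause of this step is at hand.

On these data alone, whether a hydroxy group or an amine in place of methoxymethoxy would keep the lower number remains open. So does whether an ethoxymethoxy group would lower it further.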